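A few compounds are considered here, and "the series" means these few. Any claim that something is new, unique, unknown or untested is made for them only; others in the source may bear on it.

Measured compounds, all in a functional assay on Jurkat cells (Homo sapiens) for cytotoxicity, with a stated time of 72 h; a lower number here means that less compound is needed, a higher number that more compound is needed for the effect:
Compound 1 `C=C[C@@](C)(/C=C/c1ccc(O)cc1)CCC1OC1(C)C`: > 49000 nM, a limit.
Compound 2 `C=C[C@@](C)(/C=C/c1ccc(O)cc1)CC/C=C(\C)C=O`: > 49000 nM, a limit.
Compound 3 `C=C[C@@](C)(/C=C/c1ccc(O)c(/C=C/C(=O)OCc2ccccc2)c1)CCC=C(C)C`: > 49000 nM, a limit.

Within the data shown here, on the numbers so far, compound 3 has no exact value in this assay, and the other two measured compounds are limits as well, so the three cannot be ranked. The next compound is compound 4 `C=C[C@@](C)(/C=C/c1ccc(O)c(/C=C/c2ccc(Cl)c(Cl)c2)c1)CCC=C(C)C`, and the change is 3,4-dichlorophenyl in place of benzyloxycarbonyl on a double-bonded chain carbon bound to a double-bonded chain carbon. Among the measured compounds shown here, the only step between measured compounds, a step that the two limits leave unreadable from compound 1 to compound 2, concerns a different place in the structure and has no readable size. The remaining guide is the limit of > 49000 nM in this assay, at which 3 of the 3 values shown sit. For the measured compounds named here, no measured step therefore gives a size to carry over to this exchange. Any move in this assay is expected to be small and toward a lower concentration, and a further limit is quite possible. The expected change is an at least 1.6-fold lower number from compound 3 to compound 4 (0.21 log units; that floor lies within the scatter). The estimate for compound 4 is 30000 nM, with an expected range from 10000 nM to 60000 nM.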

Compound 4, half-maximal effective concentration: > 49000 nM
Compound 4 ended at the assay's limit; the forecaster's own chance of this, stated with the estimate: 60%; middle value at least 1.6-fold (0.21 log units) from the limit.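

Compound 3 and compound 4 both sit at a limit, so the exchange of benzyloxycarbonyl for 3,4-dichlorophenyl yields no readable step. The compounds shown leave open whether any change to the shared core gives an exact value, and how these structures rank: the limit of > 49000 nM in this assay, at which 4 of the 4 values shown sit.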